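The source may report more compounds than this note shows. Statements on the series, on what has been measured and on what is new or still open speak of the compounds shown alone.

Measured so far:
Compound 1, `Cc1ccc(C2=NN(C(=S)Nc3ccccc3)C(c3ccc4c(c3)OCCO4)C2)cc1`, gives 19500 nM in a functional assay on HT-29 cells (Homo sapiens) for antiproliferative activity, read by MTT assay, with a stated time of 48 h; a higher number here means a weaker inhibitor of growth, a lower number a stronger inhibitor of growth.
Compound 2, `FC(F)(F)c1ccc(C2=NN(C(=S)Nc3ccccc3)C(c3ccc4c(c3)OCCO4)C2)cc1`, gives 97500 nM in this assay.

Among the measured compounds shown here, of the two numbers in this assay, compound 2 holds the higher one; its nearest neighbour is compound 1, and the only measured step, a 5.0-fold higher number from compound 1 to compound 2 (0.70 log units; beyond the scatter), separates the two. For the measured compounds named here, that step is the single piece of evidence on how a change of the aryl group at this position moves the number, and it shows that such a change can shift it beyond the scatter.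

Compound 3, `S=C(Nc1ccccc1)N1N=C(c2ccccc2Br)CC1c1ccc2c(c1)OCCO2`, has not yet been measured. The change from compound 2 is 2-bromophenyl in place of 4-(trifluoromethyl)phenyl on a carbon with a double bond to nitrogen. Going by the values given here, no measured step covers a 2-bromophenyl group at this position, so the expectation rests on compound 2 itself and on the size of the step of a 5.0-fold higher number from compound 1 to compound 2 (0.70 log units; beyond the scatter).

Compound 3 is therefore expected to sit near compound 2, with a step of a 2.2-fold lower number from compound 2 to compound 3 (0.34 log units; beyond the scatter), in this assay. The estimate for compound 3 is 45000 nM, with a range from 9000 nM to 200000 nM.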

Compound 3, concentration for 50% growth inhibition: > 200000 nM
Compound 3 gave a limit, no number; the forecaster's own chance of this, stated with the estimate: 15%; at least 4.4-fold (0.64 log units) between middle value and limit.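

Compound 3 does not give a number, only a limit of the assay: the limit of > 200000 nM in this assay, at which 1 of the 3 values shown sits.

Even so, the position tolerates less than compounds 1 and 2 alone could show, since 2-bromophenyl in place of 4-(trifluoromethyl)phenyl still gives an at least 2.0-fold higher number from compound 2 to compound 3 (0.31 log units; beyond the scatter). Among the compounds shown here, measured against the best of the three aryl groups, 4-methylphenyl, the change gives an at least 10-fold higher number from compound 1 to compound 3 (1.01 log units; beyond the scatter), which widens the range at this position beyond the one earlier step, a 5.0-fold higher number from compound 1 to compound 2 (0.70 log units; beyond the scatter), and leaves compound 1 with the lowest number in this assay, with steps to both others beyond the scatter.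

The compounds shown leave open whether the bromine or the change of the whole aryl group accounts for this step, as compound 3 differs from compounds 1 and 2 in both the atom carried and the group's name. On these data alone, how an unsubstituted phenyl group, or a phenyl ring carrying an amine or a carboxylic acid, would read at this position also remains open, so no ranking beyond these three aryl groups can be drawn.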